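Methoxy on the pyridine ring of compound 2

A few compounds are considered here, and "the series" means these few. Any claim that something is new, unique, unknown or untested is made for them only; others in the source may bear on it.

In a functional assay on HEK293 cells for agonist activity at Neuronal acetylcholine receptor; alpha4/beta2 (Homo sapiens), read by FLIPR (a lower number here means that less compound is needed, a higher number that more compound is needed for the effect), compound 2 `c1cncc(N2C[C@H]3CCNC[C@H]32)c1` gives 1400 nM, the highest of the three numbers seen here. Its mirror image, compound 1 `c1cncc(N2C[C@@H]3CCNC[C@@H]32)c1`, gives 410 nM in this assay, and the step of a 3.4-fold higher number from compound 1 to compound 2 (0.53 log units; beyond the scatter) rests on (the fact that compounds 1 and 2 differ only in the configuration as drawn). Compound 3 `Clc1ccc(N2C[C@H]3CCNC[C@H]32)cn1`, which carries a chloro group, gives 216 nM, so that the step of a 6.5-fold lower number from compound 2 to compound 3 (0.81 log units; beyond the scatter) shows that adding a substituent to the pyridine ring of compound 2 can bring the number down. Compound 4 `COc1cncc(N2C[C@H]3CCNC[C@H]32)c1` differs from compound 2 by methoxy in place of hydrogen on an aromatic carbon. Among the measured compounds shown here, the chloro step is the only measured guide, and the methoxy sits elsewhere on the ring, so a smaller drop is expected: a 2.3-fold lower number from compound 2 to compound 4 (0.37 log units; beyond the scatter). Compound 4 is therefore estimated at 600 nM, within 150 nM to 2500 nM.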

Compound 4, half-maximal effective concentration: 1110 nM
Beside the measured number, compound 4's estimate is 1.9-fold (0.27 log units) below it; the measured number falls inside the stated range.
By their numbers in this assay, from the lowest: compounds 3 and 1 (each within the scatter of the next); then compounds 4 and 2 (each within the scatter of the next).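

The step of a 1.3-fold lower number from compound 2 to compound 4 (0.10 log units; within the scatter) shows that methoxy on this aromatic carbon, two atoms from the ring nitrogen, does not separate compound 4 from compound 2 in this assay. A substituent on this ring therefore does not always lower the number, unlike in the step of a 6.5-fold lower number from compound 2 to compound 3 (0.81 log units; beyond the scatter), though chloro and methoxy differ in both group and place, so their effects cannot be told apart. Nothing measured here accounts for this result.

On these data alone, whether an amine, a carboxylic acid or a longer chain on this same carbon would shift the number remains open. So does the outcome of chloro at this carbon, or of methoxy on the core of compound 1.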